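Fluorine on the Fused Ring: Expected Cytotoxicity of Compound 4

A few compounds are considered here, and "the series" means these few. Any claim that something is new, unique, unknown or untested is made for them only; others in the source may bear on it.

Of the compounds shown here, three that share one core have been tested in an ADME assay on Vero cells (Chlorocebus sabaeus) for cytotoxicity, read by MTT assay, with a stated time of 72 h; on this read-out lower numbers stand for higher toxicity in this test and higher numbers for lower toxicity in this test. Compound 1 `CCOC(=O)c1c(-c2ccc(OC)cc2)oc2ccc(OCCCCCN3C(=O)/C(=N\O)c4ccccc43)cc12` gives 64 ug/mL. Compound 2 `CCOC(=O)c1c(-c2ccc(OC)cc2)oc2ccc(OCCCN3C(=O)/C(=N\OC)c4ccccc43)cc12` gives 128 ug/mL. Compound 3 `CCO/N=C1\C(=O)N(CCCCOc2ccc3oc(-c4ccc(OC)cc4)c(C(=O)OCC)c3c2)c2ccccc21` gives 64 ug/mL. Compound 3 stands level with compound 1 at the digits shown, and its gap to compound 2 also lies within the usual scatter of repeated measurements, so all three numbers are best read as one level of toxicity in this assay, with no ranking among them.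

Compound 4 `CCO/N=C1\C(=O)N(CCCCOc2ccc3oc(-c4ccc(OC)cc4)c(C(=O)OCC)c3c2)c2ccc(F)cc21` differs from compound 3 in a single place: fluoro in place of hydrogen on an aromatic carbon. Within the data shown here, no pair of measured compounds differs by this change, so there is no measured step to lean on. With only one fluorine atom entering and no ring or donor or acceptor added, the step of no change at the digits printed from compound 3 to compound 4 (within the scatter) is expected to stay within the scatter, in no particular direction. Because compound 3 gives 64 ug/mL in this assay, compound 4 is estimated at 64 ug/mL, with a range from 32 ug/mL to 128 ug/mL.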

Compound 4, half-maximal cytotoxic concentration: 32 ug/mL
Compound 4: the middle estimate sits 2.0-fold (0.30 log units) above what was measured, and the stated range covers the measured number.
By their numbers in this assay, from the lowest: compounds 4, 1, 3 and 2 (each within the scatter of the next, the first and the last beyond it).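

In this assay, putting fluoro in place of hydrogen on an aromatic carbon of the fused system gives a 2.0-fold lower number from compound 3 to compound 4 (0.30 log units; within the scatter), and this is the first step shown in which only one place changes. That step lies within the usual scatter of repeated measurements, so at this carbon, meta to a fused ring and para to a fused ring, a single fluoro cannot be told apart from hydrogen in this test, and compound 4 stays at the same level of toxicity as compound 3. No measured information on the compounds bears on this result, so the step can be described but not explained.

Going by these compounds, it remains open whether a different group on this same carbon, such as chloro, methoxy, trifluoromethyl, an amine or a carboxylic acid, would give a step beyond the scatter. On these data alone, it is also open whether fluoro on another aromatic carbon of this ring would behave as it does here, since one position and one small atom cannot show how the whole ring responds to change.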